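Swapping a Pyrazole for Trifluoromethyl on a Shared Core

The compounds below may be only part of what the source reports. "The series", "measured", "known", "first", "only" and "open" are said of these compounds alone.

Measured compounds so far:
Compound 1, `COc1cc(-c2ccnc3c(-c4ccc(C)cc4)cnn23)cc(OC)c1OC`, in a functional assay on HeLa cells (Homo sapiens) for inhibition, read by CCK-8 assay, with a stated time of 48 h (a higher number here means a weaker inhibitor, a lower number a stronger inhibitor), gives > 10000 nM, which is a limit of the measurement and not a number.
Compound 2, `COc1cc(-c2ccnc3cc(-c4ccc(-c5cnn(C)c5)cc4)nn23)cc(OC)c1OC`, in this assay gives 1830 nM.
Compound 3, `COc1cc(-c2ccnc3cc(-c4cccc5c4ccn5CO)nn23)cc(OC)c1OC`, in this assay gives 456 nM.

Of the two compounds with an actual number, compound 2 has the higher one, so it is the weaker inhibitor of that pair, and the gap to compound 3 lies beyond the usual scatter of repeat measurements. Compound 1 offers no number to compare, only (the limit of > 10000 nM in this assay, at which 1 of the 3 values shown sits).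

Compound 4, `COc1cc(-c2ccnc3cc(-c4ccc(C(F)(F)F)cc4)nn23)cc(OC)c1OC`, is built from compound 2 by a single change: trifluoromethyl in place of 1-methyl-1H-pyrazol-4-yl on an aromatic carbon. Among the compounds with values here, no measured pair in this set differs in the same way, so the size of this step cannot be read off from the data. The group that leaves carries two hydrogen-bond acceptors and a ring, while the group that enters is smaller and carries none; how much this matters in this assay is open. My expectation is a modest loss rather than a gain, a step of a 1.7-fold higher number from compound 2 to compound 4 (0.24 log units; within the scatter). Compound 4 is therefore estimated at 3200 nM, with a likely range from 800 nM to 12000 nM.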

Compound 4, half-maximal inhibitory concentration: 1840 nM
The estimate for compound 4 lay 1.7-fold (0.24 log units) above the measured number; the measured number falls inside the stated range.
By their numbers in this assay, from the lowest: compound 3; then compounds 2 and 4 (each within the scatter of the next). At a limit, above all of these: compound 1.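

In this assay, the step is a 1.0-fold higher number from compound 2 to compound 4 (0.00 log units; within the scatter), so trading 1-methyl-1H-pyrazol-4-yl for trifluoromethyl on this aromatic carbon, para to a large group, gives two compounds that cannot be told apart. Within the data shown here, this is the first pair in the set that differs in only one place, and it shows that, in this assay, the position holds a group with a ring and hydrogen-bond acceptors and a smaller group with neither, without any difference that can be read. Nothing measured here gives a reason for this match.

The compounds shown leave open whether a group of another kind at this position, such as an amine or a carboxylic acid, would give a number like these two or one clearly higher or lower. A single pair also cannot say whether the same swap would behave alike on a different core, such as the core of compound 1, or whether the match holds only on the shared core of compound 2 and compound 4.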